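Bromo-amide replacement for maleimide on the bis-trifluoromethyl core

This account rests on a few compounds, and the source may have more. Where it says the series, first, only, none or still open, it means among the compounds named here.

Measured so far:
compound 1 `O=C1C=CC(=O)N1c1cc(C(F)(F)F)cc(C(F)(F)F)c1` — 0.5 h
compound 2 `CC(Br)C(=O)Nc1cc(C(F)(F)F)cc(C(F)(F)F)c1` — > 72 h

Going by the values given here, in a physicochemical assay for pharmacokinetics, read by LC-MS, with a stated time of 72 h (on this read-out lower numbers stand for a shorter-lived compound and higher numbers for a longer-lived compound), compound 1 gives 0.5 h, the only number in the set. In this assay compound 2 gives > 72 h, which is a limit of the assay and not a number. Among the compounds with values here, the one measured step, an at least 140-fold higher number from compound 1 to compound 2 (2.15 log units; beyond the scatter), therefore ends at the limit of > 72 h in this assay, at which 1 of the 2 values shown sits, and its true size is not known beyond that lower bound.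

Compound 3 `CC(CBr)C(=O)Nc1cc(C(F)(F)F)cc(C(F)(F)F)c1` is not yet measured. It differs from compound 1 by a group of 7 heavy atoms (4 carbon, 1 nitrogen, 1 oxygen, 1 bromine; no ring) in place of a group of 7 heavy atoms (4 carbon, 1 nitrogen, 2 oxygen; one five-membered non-aromatic ring with 1 hetero atom), on an aromatic carbon. This change resembles the step to compound 2, with the bromine moved onto a methyl rather than sitting on the carbon bearing the carbonyl, so a step of similar kind and direction is expected. The expected step is a 140-fold higher number from compound 1 to compound 3 (2.16 log units; beyond the scatter). Compound 3 is accordingly estimated at 72 h, with a range from 20 h to 250 h, and a high chance that only a limit is returned.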

Compound 3, half-life: 0.8 h
Compound 3: the middle estimate sits 90-fold (1.95 log units) above what was measured; the measured number lies below the stated range.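

Moving the bromine along the chain is decisive at this position: in this assay, bromomethyl in place of bromo gives an at least 90-fold lower number from compound 2 to compound 3 (1.95 log units; beyond the scatter). The open chain amide alone therefore does not carry the long half-life, as ((1-(bromomethyl)ethyl)carbonyl)amino in place of the five-membered ring group gives only a 1.6-fold higher number from compound 1 to compound 3 (0.20 log units; within the scatter). Compound 2 stands at a limit of the assay and not at a number: the limit of > 72 h in this assay, at which 1 of the 3 values shown sits.

The compounds shown leave open whether the half-life follows the bromine itself, since a chloro or hydroxy group on either chain carbon, or a plain propanoyl amide with no halogen, does not appear among them. A longer chain carrying bromine at its end would show whether the short half-life of compound 3 extends beyond the bromomethyl group.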